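Swapping the aryl group on the triazole nitrogen

The source may hold more compounds than are shown below. What is called first, only, known or untested is meant among the compounds shown, and "the series" means these compounds.

Measured so far:
compound 1, `N#CC1=C(N)Oc2c(c3nc4ccccc4nc3c3ccccc23)C12C(=O)N(Cc1cnnn1-c1cccc(S(N)(=O)=O)c1)c1ccccc12`: > 50000 nM
compound 2, `CCOc1ccc(-n2nncc2CN2C(=O)C3(C(C#N)=C(N)Oc4c(N)cc5nc6ccccc6nc5c43)c3ccccc32)cc1`: > 50000 nM

Both compounds were tested in an ADME assay on L02 cells (Homo sapiens) for antiproliferative activity, read by MTT assay, with a stated time of 48 h; a higher number here means a weaker inhibitor, a lower number a stronger inhibitor. Compound 1 gives > 50000 nM, which is a limit of the assay rather than a number. Compound 2 gives > 50000 nM, again a limit. Compound 2 therefore stands at the limit of > 50000 nM in this assay, at which 2 of the 2 values shown sit, and nothing places it apart from compound 1 on the numbers shown.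

Compound 3, `Cc1cc(C)c(-n2nncc2CN2C(=O)C3(C(C#N)=C(N)Oc4c(N)cc5nc6ccccc6nc5c43)c3ccccc32)c(C)c1`, is not yet measured. It differs from compound 2 in one place: 2,4,6-trimethylphenyl in place of 4-ethoxyphenyl on an aromatic nitrogen. Going by the values given here, no measured pair of compounds shows what such a change does in this assay, so the only guide is that the two compounds measured both end at the limit. The expectation is that the step of a number no higher from compound 2 to compound 3 (the limit leaves the size open) stays within the usual scatter, with no clear direction. Compound 3 is estimated at 50000 nM, within a range from 20000 nM to 120000 nM, and most likely the assay will again report only a limit.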

Compound 3, half-maximal inhibitory concentration: > 50000 nM
Compound 3 gave a limit, no number (the forecaster's own chance of this, stated with the estimate: 80%); the middle value sits exactly at the limit.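

No step can be read from compound 2 to compound 3, since swapping 4-ethoxyphenyl for 2,4,6-trimethylphenyl leaves both compounds at a limit rather than a number in this assay: the limit of > 50000 nM in this assay, at which 3 of the 3 values shown sit.

The compounds shown leave open how far apart compound 1, compound 2 and compound 3 truly lie, and whether any group on that aromatic nitrogen gives a readable value.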